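Hydroxymethoxyphenyl Chalcone Variant of Compound 2

The source may hold more compounds than are shown below. What is called first, only, known or untested is meant among the compounds shown, and "the series" means these compounds.

Compound 2 `O=C(/C=C/c1cccc(O)c1)c1cccc(-n2cc(-c3ccc(Cl)cc3)[nH]c2=O)c1` gives 1570 nM in a functional assay on 786-0 cells (Homo sapiens) for inhibition (a lower number here means a stronger inhibitor of growth, a higher number a weaker inhibitor of growth), the lowest of the three numbers measured, though both others lie within the scatter of it. Compound 1 `O=C(/C=C/c1cccc(O)c1)c1cccc(-n2cc(-c3ccccc3)[nH]c2=O)c1` gives 2980 nM, and the step of a 1.9-fold lower number from compound 1 to compound 2 (0.28 log units; within the scatter) stays within the scatter. For the measured compounds named here, compound 3 `COc1ccc(-c2cn(-c3cccc(C(=O)/C=C/c4cc(OC)c(OC)c(OC)c4)c3)c(=O)[nH]2)cc1` gives 1610 nM, again within the scatter of compound 2; compound 3 differs from compound 2 in more than one place, so no single step joins them. Compound 4 `COc1cc(/C=C/C(=O)c2cccc(-n3cc(-c4ccc(Cl)cc4)[nH]c3=O)c2)ccc1O` carries 4-hydroxy-3-methoxyphenyl in place of 3-hydroxyphenyl on a double-bonded chain carbon bound to a double-bonded chain carbon. Going by the values given here, no measured step alters only this part of the structure, so there is nothing that points to a shift beyond the scatter in either direction. In this assay compound 4 is expected to give 1500 nM, between 600 nM and 4000 nM. The step of a 1.0-fold lower number from compound 2 to compound 4 (0.02 log units; within the scatter) is thus expected to stay within the scatter.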

Compound 4, concentration for 50% growth inhibition: 2070 nM
Beside the measured number, compound 4's estimate is 1.4-fold (0.14 log units) below it; low and high end bracket the measured number.
By their numbers in this assay, from the lowest: compounds 2, 3, 4 and 1 (each within the scatter of the next).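

In this assay, for the compounds shown here, 4-hydroxy-3-methoxyphenyl in place of 3-hydroxyphenyl gives a 1.3-fold higher number from compound 2 to compound 4 (0.12 log units; within the scatter) at a site that no earlier step had touched. The position on a double-bonded chain carbon bound to a double-bonded chain carbon therefore accepts this larger group with no shift beyond the scatter. No supporting data bear on why the number holds.

This single step cannot separate the added methoxy from the moved hydroxy. On these data alone, whether an amine or a carboxylic acid on this aromatic ring would shift the number beyond the scatter remains open.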